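The compounds below may be only part of what the source reports. "The series", "measured", "known", "first", "only" and "open" are said of these compounds alone.

In a functional assay on SF-268 cells (Homo sapiens) for antiproliferative activity, read by MTT assay, with a stated time of 96 h (on this read-out higher numbers stand for weaker inhibition and lower numbers for stronger inhibition), compound 1 `O=C1NC(=O)C2(CSC3=C2C(=O)c2ncccc2C3=O)N1` gives 3100 nM and compound 2 `CCCCc1ccc(N2C(=O)NC3(CSC4=C3C(=O)c3ncccc3C4=O)C2=O)cc1` gives 400 nM, the lower of the two numbers. Compound 3 `CC(C)(C)c1ccc(N2C(=O)NC3(CSC4=C3C(=O)c3ncccc3C4=O)C2=O)cc1` differs from compound 2 by tert-butyl in place of butyl on an aromatic carbon, para to a large group: tert-butyl in place of butyl on an aromatic carbon. Within the data shown here, only one measured step bears on this change, and only indirectly. That step, a 7.8-fold lower number from compound 1 to compound 2 (0.89 log units; beyond the scatter), is modest but beyond the scatter, and it comes from 4-butylphenyl in place of hydrogen on an amide-type nitrogen in a ring. The series holds no measured comparison of butyl with any other group at this position, so no direction can be argued from the data, and no shift beyond the scatter is expected in this assay. The expected step is a 1.1-fold higher number from compound 2 to compound 3 (0.05 log units; within the scatter). Compound 3 is estimated at 450 nM, with an expected range of 180 nM to 1100 nM.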

Compound 3, half-maximal inhibitory concentration: 500 nM
Estimate against measurement, compound 3: 1.1-fold (0.05 log units) below, and the stated range covers the measured number.
By their numbers in this assay, from the lowest: compounds 2 and 3 (each within the scatter of the next); then compound 1.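

In this assay, tert-butyl in place of butyl gives a 1.3-fold higher number from compound 2 to compound 3 (0.10 log units; within the scatter) so these two four-carbon groups are not told apart at this position. 4-(tert-butyl)phenyl in place of hydrogen on the amide-type nitrogen still gives a 6.2-fold lower number from compound 1 to compound 3 (0.79 log units; beyond the scatter) so the step away from compound 1 is not confined to the straight butyl chain. No supporting data on hand bear on the reason for either step.

The compounds shown leave open how a carboxylic acid, an amine or a longer chain would read at this position. They also leave open what a plain phenyl without either four-carbon group would give, which would separate the contribution of the ring from that of the butyl or tert-butyl group.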